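The source may report more compounds than this note shows. Statements on the series, on what has been measured and on what is new or still open speak of the compounds shown alone.

Two compounds share one core and differ only in the group on an aromatic carbon of its benzene ring. Compound 1 `CCCCN(c1nc2c(C(=O)O)cccc2o1)[C@H](C)c1ccc(-c2ccccc2-c2nnn[nH]2)cc1` carries a carboxy group there; in an ADME assay on the whole organism (plasma, Macaca fascicularis) for protein binding, read by LC-MS, using equilibrium dialysis and cassette dosing, with a stated time of 24 h, at a dose of 1 mg/kg by the oral route (on this read-out higher numbers stand for a larger free fraction and lower numbers for a smaller free fraction), compound 1 gives 0.000285. Compound 2 `CCCCN(c1nc2c(-c3nccn3C)cccc2o1)[C@H](C)c1ccc(-c2ccccc2-c2nnn[nH]2)cc1` carries a 1-methyl-1H-imidazol-2-yl group instead, and in this assay compound 2 gives 0.00299. Among the measured compounds shown here, the only step measured so far is a 10-fold higher number from compound 1 to compound 2 (1.02 log units; beyond the scatter). On these two numbers compound 2 stands highest, with compound 1 as its nearest neighbour.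

The next compound, compound 3 `CCCCN(c1nc2c(C(=O)NS(C)(=O)=O)cccc2o1)[C@H](C)c1ccc(-c2ccccc2-c2nnn[nH]2)cc1`, changes the same position again: (methylsulfonyl)carbamoyl in place of 1-methyl-1H-imidazol-2-yl on an aromatic carbon. For the measured compounds named here, no measured step involves a (methylsulfonyl)carbamoyl group, so the one step that bears on this change is the exchange at this very position from compound 1 to compound 2, which was large. Since compound 3 gives up the group that stood at the top, a downward step in this assay is expected for compound 3, of roughly that size, namely a 6.0-fold lower number from compound 2 to compound 3 (0.78 log units; beyond the scatter). The estimate for compound 3 in this assay is therefore 0.0005, with a plausible range from 0.00012 to 0.002.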

Compound 3, unbound fraction: 0.00103
Estimate against measurement, compound 3: 2.1-fold (0.31 log units) below; low and high end bracket the measured number.
By their numbers in this assay, from the lowest: compound 1; then compound 3; then compound 2.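

With a third group at this position, this assay places the (methylsulfonyl)carbamoyl group between the other two, so the position does not simply give a high number for one group and a low number for the other: the change from the ring-bearing group gives a 2.9-fold lower number from compound 2 to compound 3 (0.46 log units; beyond the scatter) and the change from the carboxy group gives a 3.6-fold higher number from compound 1 to compound 3 (0.56 log units; beyond the scatter). Methanesulfonamido in place of hydroxy keeps the carbonyl carbon on the aromatic carbon, yet this small exchange still moves the number beyond the scatter, though less far than the exchange of carboxy for 1-methyl-1H-imidazol-2-yl, which gave a 10-fold higher number from compound 1 to compound 2 (1.02 log units; beyond the scatter). Nothing available here accounts for this order of the three groups.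

From the compounds shown here alone, it remains open whether a plain primary amide, with no methylsulfonyl group on the nitrogen, would fall nearer compound 1 or compound 3. Going by these compounds, it is equally open whether a phenylsulfonyl group in place of the methylsulfonyl, or a 1-methyl-1H-imidazol-2-yl analogue lacking the methyl group, would shift the number beyond the scatter.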